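The compounds below may be only part of what the source reports. "The series", "measured", "known", "first", "only" and "open" are said of these compounds alone.

Compound 2, `Cc1cc2ccccc2nc1-c1cn(-c2ccc(F)cc2)nn1`, was examined in a functional assay on HeLa cells (Homo sapiens) for cytotoxicity, read by MTT assay, with a stated time of 24 h; on this read-out lower numbers stand for stronger inhibition and higher numbers for weaker inhibition. In this assay compound 2 gives only a limit, > 100 ug/mL, and no number. Compound 1, `Cc1cc2ccccc2nc1-c1cn(CCC(F)(F)C(F)(F)C(F)(F)C(F)(F)C(F)(F)C(F)(F)C(F)(F)C(F)(F)F)nn1`, shares the same core and also sits at a limit in this assay, where compound 1 gives > 100 ug/mL. For the measured compounds named here, both values shown therefore stand at the limit of > 100 ug/mL in this assay, at which 2 of the 2 values shown sit, so compound 2 cannot be placed on a scale against any other compound, and no step between two measured compounds is available.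

Compound 3, `CCCCCc1cc2ccccc2nc1-c1cn(-c2ccc(F)cc2)nn1`, has not yet been measured in this assay. It differs from compound 2 in one place: butyl in place of hydrogen on a saturated chain carbon bound to an aromatic carbon. Going by the values given here, with no measured step to lean on, the size of the change is open; one expects at most a modest step toward stronger inhibition, and a result that stays within the usual scatter of compound 2 would be no surprise. For compound 3 the estimate in this assay is 90 ug/mL, with a range from 30 ug/mL to 250 ug/mL. The step expected from compound 2 to compound 3 is an at least 1.1-fold lower number from compound 2 to compound 3 (0.04 log units; that floor lies within the scatter).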

Compound 3, half-maximal inhibitory concentration: > 100 ug/mL
Compound 3: only a limit was reported (the forecaster's own chance of this, stated with the estimate: 55%); at least 1.1-fold (0.04 log units) between middle value and limit.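

In this assay no step can be read from compound 2 to compound 3, since both compounds give only a limit and no number: the limit of > 100 ug/mL in this assay, at which 3 of the 3 values shown sit. The compounds shown leave open how far the true values of these compounds lie from that limit, and whether any change on the shared core would give a measurable value.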